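Iodo in place of hydrogen on the compound 3 aromatic ring

The source may hold more compounds than are shown below. What is called first, only, known or untested is meant among the compounds shown, and "the series" means these compounds.

Of the compounds shown here, three with a shared core have been measured in an assay on 1321N1 cells for antagonist activity at P2Y purinoceptor 6 (Mus musculus), read by FLIPR and calcium flux; a lower number here means a stronger inhibitor, a higher number a weaker inhibitor. Compound 3 `O=[N+]([O-])C1=Cc2ccccc2OC1C(F)(F)F` gives 185000 nM, the highest of the three numbers. Compound 2 `O=[N+]([O-])C1=Cc2cc(Cl)ccc2OC1C(F)(F)F` gives 30800 nM, and compound 1 `O=[N+]([O-])C1=Cc2cccc(Cl)c2OC1C(F)(F)F` gives 15200 nM. Both carry chloro on an aromatic carbon where compound 3 carries hydrogen, and the two steps to compound 3 are a 6.0-fold higher number from compound 2 to compound 3 (0.78 log units; beyond the scatter) and a 12-fold higher number from compound 1 to compound 3 (1.09 log units; beyond the scatter).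

Compound 4 `O=[N+]([O-])C1=Cc2cc(I)ccc2OC1C(F)(F)F` differs from compound 3 by iodo in place of hydrogen on an aromatic carbon. Among the measured compounds shown here, this is the place at which compound 2 carries chloro, so the step from compound 2 to compound 3 bears most directly on it, although no measured step tells how iodo compares with chloro. Reading the change in reverse, a lower number for compound 4 than for compound 3 is expected, of a size near the chloro step or somewhat larger. Compound 4 is therefore estimated at 20000 nM, with a range from 6000 nM to 60000 nM, which would mean an expected step of a 9.3-fold lower number from compound 3 to compound 4 (0.97 log units; beyond the scatter).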

Compound 4, half-maximal inhibitory concentration: 28700 nM
Estimate against measurement, compound 4: 1.4-fold (0.16 log units) below, and the stated range covers the measured number.
By their numbers in this assay, from the lowest: compounds 1, 4 and 2 (each within the scatter of the next, the first and the last beyond it); then compound 3.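

In this assay, iodo on this aromatic carbon gives a 6.4-fold lower number from compound 3 to compound 4 (0.81 log units; beyond the scatter), so the lower number relative to hydrogen at this place is not confined to chloro. Iodo and chloro at this place cannot be told apart, with a 1.1-fold lower number from compound 2 to compound 4 (0.03 log units; within the scatter), and exchanging one halogen for the other leaves the number unchanged within the scatter. No measurement of any property bears on why these two groups give such similar numbers.

Going by these compounds, whether fluoro or bromo would fit the same picture stays open, as does whether a group other than a halogen, such as an amine, a methoxy group or a carboxylic acid, would lower the number on this carbon. Also open is how iodo would behave at the place where compound 1 carries chloro, as the compounds shown hold iodo at this one place only.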